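The source may report more compounds than this note shows. Statements on the series, on what has been measured and on what is new or still open speak of the compounds shown alone.

Compound 1 `CC(=O)c1cc(-c2ccc(F)cc2)cc2cc(-c3ccccc3)[nH]c12` gives 73.8% in a functional assay on MCF7 cells (Homo sapiens) for cytotoxicity, read by MTT assay, with a stated time of 2 days, tested at 10 uM; a lower number here means a stronger effect, a higher number a weaker effect of the compound at the concentration tested. Compound 2 `COc1ccc(-c2cc(C(C)=O)c3[nH]c(-c4ccccc4)cc3c2)cc1` differs from compound 1 by methoxy in place of fluoro on an aromatic carbon; in this assay compound 2 gives 49.5%, and the step is a number 24.3 percentage points lower from compound 1 to compound 2 (beyond the scatter). Compound 3 `CC(=O)c1cc(-c2ccccc2)cc2cc(-c3ccc(F)cc3)[nH]c12` gives 91.9% in this assay, the highest of the three values, above both compound 1 and compound 2; the difference between the cores of compound 1 and compound 3 is not broken down here. Compound 4 `COc1ccc(-c2cc3cc(-c4ccccc4)cc(C(C)=O)c3[nH]2)cc1` awaits measurement and differs from compound 3 by methoxy in place of fluoro on an aromatic carbon, the same change already made from compound 1 to compound 2, at a place described in the same words. The step of a number 23.9 percentage points lower from compound 3 to compound 4 (beyond the scatter) is expected to be of a similar size and direction because compound 2 against compound 1 showed a number 24.3 percentage points lower from compound 1 to compound 2 (beyond the scatter). Compound 4 is therefore estimated at 68%, expected between 50% and 86%.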

Compound 4, a percentage reported as activity, at one concentration (the size of the read-out at that concentration, not a potency): 64.5%
Estimate against measurement, compound 4: 3.5 percentage points above; measured number inside the range.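

Methoxy in place of fluoro gives a number 27.4 percentage points lower from compound 3 to compound 4 (beyond the scatter) in this assay. Set beside the step on the core of compound 1, the change carries over between these two cores in direction and in size: the same change on two cores in this assay, a number 24.3 percentage points lower (beyond the scatter) from compound 1 to compound 2 and a number 27.4 percentage points lower (beyond the scatter) from compound 3 to compound 4, 3.1 percentage points apart, within the scatter of two such steps This rests on two pairs and one read-out at a single concentration, and it does not show that the change would carry to any other core or why the step takes this size.

Still open, from the compounds shown here alone, is whether other groups on the same aromatic carbon, such as an amine, a carboxylic acid or a longer alkoxy chain, would also carry from one core to the other. The compounds shown also leave open how the acetyl group contributes, since it is common to all of them.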